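A few compounds are considered here, and "the series" means these few. Any claim that something is new, unique, unknown or untested is made for them only; others in the source may bear on it.

For the measured compounds named here, in a functional assay on the whole organism (Tail, strain ICR) with Mus musculus as the target, in the tail flick test, with a stated time of 150 min, at a dose of 25 umol/kg by the oral route (a lower number here means a weaker effect, a higher number a stronger effect of the compound at the dose given), compound 3 `O=C(O)C[C@H](NC(=O)CN(c1nc(Cl)nc2[nH]cnc12)C1CC1)C(=O)O` gives 11.6%, the second highest of the three numbers measured so far. Compound 1 `N=C(N)NCCC[C@H](NC(=O)CN(c1nc(Cl)nc2[nH]cnc12)C1CC1)C(=O)OCc1ccccc1` gives 6.12%, which lies within the scatter of compound 3, while compound 2 `O=C(CN(c1nc(Cl)nc2[nH]cnc12)C1CC1)N[C@@H](CCC(=O)OCc1ccccc1)C(=O)OCc1ccccc1` gives 44.5%, well beyond it. Going by the values given here, the only step between measured compounds, a number 38.4 percentage points higher from compound 1 to compound 2 (beyond the scatter), is large, but it replaces a different group at a different place in the shared core's side chain than the change now in question, so it bears on it only loosely. Compound 4 `O=C(O)CNC(=O)CN(c1nc(Cl)nc2[nH]cnc12)C1CC1` differs from compound 3 in that (hydrogen in place of carboxymethyl on a saturated chain carbon bound to an amide-type nitrogen and a carbonyl carbon). Among the compounds with values here, with no closely matching step to lean on, the expected change is none beyond the scatter, namely a number 1.6 percentage points lower from compound 3 to compound 4 (within the scatter). Compound 4 is therefore estimated at 10%, with a range from 0% to 30%.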

Compound 4, a percentage reported as activity, at one dose (the size of the read-out at that dose, not a potency): 9.08%
For compound 4 the middle estimate is 0.9 percentage points above the measured one; measured number inside the range.
By their numbers in this assay, from the lowest: compounds 1, 4 and 3 (each within the scatter of the next); then compound 2.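

In this assay, putting hydrogen in place of carboxymethyl on a saturated chain carbon bound to an amide-type nitrogen and a carbonyl carbon gives a number 2.5 percentage points lower from compound 3 to compound 4 (within the scatter) and so leaves the read-out unchanged within the scatter. At this dose, then, the read-out does not tell carboxymethyl from hydrogen at this place. Nothing shown gives a reason for this result. From the compounds shown here alone, whether a small methyl group, an amine or a longer chain ending in a carboxylic acid at this place would change the read-out stays open. So does whether the same holds at other doses.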